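Carbamoyl restored at the carbonyl carbon of compound 2

The source may report more compounds than this note shows. Statements on the series, on what has been measured and on what is new or still open speak of the compounds shown alone.

Among the compounds with values here, compound 2 `Cc1cn(C2CC(N=[N+]=[N-])C(COC(=O)CCCC(=O)O)O2)c(=O)[nH]c1=O` holds the only plain number in an ADME assay on the whole organism (serum) with Homo sapiens as the target; a higher number here means that the compound lasts longer, a lower number that the compound disappears faster; there compound 2 gives 30 h. Compound 1 `Cc1cn(C2CC(N=[N+]=[N-])C(COC(=O)NCCCO)O2)c(=O)[nH]c1=O` gives > 48 h in this assay, and that is a limit of the assay, namely (the limit of > 48 h in this assay, at which 1 of the 2 values shown sits). Within the data shown here, the single measured step is an at least 1.6-fold lower number from compound 1 to compound 2 (0.20 log units; that floor lies within the scatter). Compound 3 `Cc1cn(C2CC(N=[N+]=[N-])C(COC(=O)NCCCN)O2)c(=O)[nH]c1=O` differs from compound 2 by (3-aminopropyl)amino in place of 3-carboxypropyl on a carbonyl carbon, which brings back the carbamoyl group that compound 1 carries. On that step alone, compound 3 is expected to move back up, a 1.7-fold higher number from compound 2 to compound 3 (0.22 log units; within the scatter). Compound 3 is therefore estimated at 50 h, with a range from 20 h to 120 h.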

Compound 3, half-life: > 48 h
Compound 3: no number, only a limit; the forecaster's own chance of this, stated with the estimate: 50%; the middle value lies beyond the limit too.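

In this assay compound 3 gives > 48 h, which is a limit of the assay. With (3-aminopropyl)amino in place of 3-carboxypropyl on this carbonyl carbon, the change gives an at least 1.6-fold higher number from compound 2 to compound 3 (0.20 log units; that floor lies within the scatter), so a second carbamoyl compound reaches the limit, though the floor of this step does not separate it from compound 2. The step between compound 1 and compound 3 cannot be read, and the two compounds share this limit: the limit of > 48 h in this assay, at which 2 of the 3 values shown sit.

On these data alone, what stays open is how far either carbamoyl compound lasts beyond that limit, and how a longer chain or a terminal carboxylic acid on the carbamoyl nitrogen would compare.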